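A Butyl Chain in Place of a Nitrophenyl Group

This account rests on a few compounds, and the source may have more. Where it says the series, first, only, none or still open, it means among the compounds named here.

Three compounds have been measured in a functional assay on A549 cells (Homo sapiens) for inhibition, read by sulforhodamine B assay, with a stated time of 48 h, tested at 50 uM; on this read-out lower numbers stand for less inhibition of growth and higher numbers for more inhibition of growth at the one concentration tested:
compound 1 `CCOc1ccc([C@@H]2CC(=O)c3cc(CC=C(C)C)c(OC)cc3O2)cc1` gives 37%
compound 2 `COc1cc2c(cc1CC=C(C)C)C(=O)C[C@@H](c1ccc(Oc3cccc([N+](=O)[O-])c3)cc1)O2` gives 37%
compound 3 `COc1ccc([C@@H]2C/C(=N/O)c3cc(CC=C(C)C)c(OC)cc3O2)cc1` gives 66%

For the measured compounds named here, compound 2 stands level with compound 1, and the two share the lowest value of the three; compound 3 lies higher, but no single-place step connects it to compound 2. Compound 4 `CCCCOc1ccc([C@@H]2CC(=O)c3cc(CC=C(C)C)c(OC)cc3O2)cc1` differs from compound 2 by butyl in place of 3-nitrophenyl on an oxygen on an aromatic ring. Going by the values given here, the one step that bears on this change is no change at the digits printed from compound 1 to compound 2 (within the scatter), where replacing ethyl with 3-nitrophenyl on that oxygen left the number unchanged. Going back to an alkyl chain, now butyl, is therefore expected to produce no step beyond the scatter, a number 1 percentage points higher from compound 2 to compound 4 (within the scatter). Compound 4 is estimated at 38%, with a range from 24% to 54%.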

Compound 4, percent growth inhibition at one concentration: 37%
Compound 4: middle estimate off by 1 percentage points, on the high side; measured number inside the range.
By their numbers in this assay, from the lowest: compounds 1, 2 and 4 (each within the scatter of the next); then compound 3.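

In this assay, the group on this oxygen can now be swapped in both directions without leaving the scatter: butyl in place of 3-nitrophenyl (no change at the digits printed from compound 2 to compound 4 (within the scatter)) and butyl in place of ethyl (no change at the digits printed from compound 1 to compound 4 (within the scatter)). An alkyl chain of either length and the 3-nitrophenyl ring therefore read alike at this one concentration. Nothing measured here offers a reason for this sameness. As far as these compounds go, whether an amine, a carboxylic acid or a chain longer than butyl on this oxygen would shift the number remains open. So does whether this sameness holds at other concentrations.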